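The source may hold more compounds than are shown below. What is called first, only, known or untested is meant among the compounds shown, and "the series" means these compounds.

Measured so far:
compound 1, `Cn1cncc1C(OCc1ccc(C#N)cc1C#Cc1ccccn1)c1ccc(C#N)cc1`, > 0.1 nM in a functional assay on NIH3T3 cells (Mus musculus); on this read-out lower numbers stand for an effect already at smaller amounts and higher numbers for an effect only at larger amounts of compound
compound 2, `Cn1cncc1C(OCc1ccc(C#N)cc1C#CCCc1ccccc1)c1ccc(C#N)cc1`, 130 nM in this assay

The value of compound 1 in this assay is a limit of the assay, not a number. Within the data shown here, compound 2 therefore stands as the only numbered value in this assay; its 130 nM has no second number to be set against. Among the measured compounds shown here, the one step between measured compounds, a step that the limit leaves unreadable from compound 1 to compound 2, cannot be read in size because of the limit of > 0.1 nM in this assay, at which 1 of the 2 values shown sits.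

Compound 3, `Cn1cncc1C(OCc1ccc(C#N)cc1-c1ccc(-c2ccccc2)cc1)c1ccc(C#N)cc1`, differs from compound 2 by 4-phenylphenyl in place of 4-phenylbut-1-yn-1-yl on an aromatic carbon, a change made at the same place as the step from compound 1 to compound 2 but with a different group entering. For the measured compounds named here, no measured step bears readably on this change, so the expectation rests on the value of compound 2 alone. The step from compound 2 to compound 3 in this assay is expected to be a 1.2-fold higher number from compound 2 to compound 3 (0.06 log units; within the scatter), within the usual scatter. On this basis compound 3 is estimated at 150 nM in this assay, with a range of 30 nM to 700 nM.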

Compound 3, half-maximal effective concentration: < 0.1 nM
Compound 3: a limit, no number (the forecaster's own chance of this, stated with the estimate: 5%); at least 1500-fold (3.17 log units) between middle value and limit.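

In this assay, among these compounds, putting 4-phenylphenyl in place of 4-phenylbut-1-yn-1-yl on this aromatic carbon, ortho to a large group and meta to a cyano group, gives an at least 1300-fold lower number from compound 2 to compound 3 (3.11 log units; beyond the scatter); this is the first readable sign that the read-out responds strongly to the group held at this position. The value of compound 3, < 0.1 nM, is a limit and not a number. In this assay there is also a number no higher from compound 1 to compound 3 (the limit leaves the size open) at this aromatic carbon. The change removes the triple bond outside aromatic rings and brings a second six-membered aromatic ring of carbon only, while neither group has hydrogen-bond donors or acceptors, so the step goes with a change in the carbon framework alone.

Which of these two differences carries the step remains open, and so does whether a single phenyl group on this aromatic carbon, or a 4-phenylphenyl group carrying an amine or a carboxylic acid, would stay level with compound 3 in this assay. Neither that step to compound 3 from compound 1 nor the step from compound 1 to compound 2 can be read in size: the limit of > 0.1 nM in this assay, at which 1 of the 3 values shown sits.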